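Swapping the heteroaryl arm on a shared diketopiperazine-like core

The source may hold more compounds than are shown below. What is called first, only, known or untested is meant among the compounds shown, and "the series" means these compounds.

Compounds measured so far:
compound 1 `O=c1[nH]/c(=C\c2nc[nH]c2C2CC2)c(=O)[nH]/c1=C\c1cccc(Oc2ccc(F)cc2)c1` — 15.2 nM
compound 2 `O=c1[nH]/c(=C\c2ccccn2)c(=O)[nH]/c1=C\c1cccc(Oc2ccc(F)cc2)c1` — 49.1 nM
compound 3 `O=c1[nH]/c(=C\C2CCCCC2)c(=O)[nH]/c1=C\c1cccc(Oc2ccc(F)cc2)c1` — > 1000 nM (a limit)

All three share one core and differ only in the group on a double-bonded chain carbon bound to an aromatic carbon. In a functional assay on NCI-H460 cells (Homo sapiens) for cytotoxicity, read by MTT assay, with a stated time of 72 h (on this read-out lower numbers stand for stronger inhibition and higher numbers for weaker inhibition), compound 1 gives 15.2 nM, the lowest number of the two actual values shown. Compound 2 gives 49.1 nM, a step of a 3.2-fold higher number from compound 1 to compound 2 (0.51 log units; beyond the scatter). Compound 3 reaches only a limit of this assay, > 1000 nM; this is the step of an at least 65-fold higher number from compound 1 to compound 3 (1.81 log units; beyond the scatter), and the limit of > 1000 nM in this assay, at which 1 of the 3 values shown sits, marks where that limit sits.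

Compound 4 `O=c1[nH]/c(=C\c2ccc(Cl)o2)c(=O)[nH]/c1=C\c1cccc(Oc2ccc(F)cc2)c1` is the next case. The change is 5-chlorofuran-2-yl in place of 5-cyclopropyl-1H-imidazol-4-yl on a double-bonded chain carbon bound to an aromatic carbon. The entering group is aromatic and five-membered like the leaving one but carries no hydrogen-bond donor, and in that respect it resembles the pyridin-2-yl of compound 2 more than the cyclohexyl of compound 3. The two measured steps from compound 1 both go to higher numbers, modest for compound 2 and large for compound 3. A modest rise beyond the scatter is therefore expected, roughly a 5.3-fold higher number from compound 1 to compound 4 (0.72 log units; beyond the scatter). For compound 4 the estimate in this assay is 80 nM, with a range from 25 nM to 300 nM.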

Compound 4, half-maximal inhibitory concentration: 180 nM
For compound 4 the middle estimate is 2.3-fold (0.35 log units) below the measured one, within the range that was stated.
By their numbers in this assay, from the lowest: compound 1; then compound 2; then compound 4. At a limit, above all of these: compound 3.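

The step of a 12-fold higher number from compound 1 to compound 4 (1.07 log units; beyond the scatter) shows that, in this assay, a five-membered aromatic ring at this place does not by itself keep the level of compound 1. The step of a 3.7-fold higher number from compound 2 to compound 4 (0.56 log units; beyond the scatter) adds that aromatic groups at this place also differ clearly among themselves, so being aromatic is not the whole story. Compound 4 still improves on cyclohexyl, with an at least 5.5-fold lower number from compound 3 to compound 4 (0.74 log units; beyond the scatter), but that step is only a bound, as compound 3 stands at a limit: the limit of > 1000 nM in this assay, at which 1 of the 4 values shown sits.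

The change from compound 1 to compound 4 swaps the ring, removes the cyclopropyl and adds chlorine all at once, so the compounds shown cannot say which of these matters. A plain 1H-imidazol-4-yl or a 5-cyclopropylfuran-2-yl would pull these changes apart.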